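Swapping 4-methoxyphenyl for ethoxycarbonyl in compound 1

The source may hold more compounds than are shown below. What is called first, only, known or untested is meant among the compounds shown, and "the series" means these compounds.

Measured so far in a functional assay on HT-29 cells (Homo sapiens) for inhibition, read by MTT assay, with a stated time of 48 h; a higher number here means a weaker inhibitor, a lower number a stronger inhibitor:
- Compound 1 `COc1ccc(CSc2nnc(-c3cc(OC)c(OC)c(OC)c3)n2-c2ccc(OC)cc2)cc1`: > 60000 nM, a limit of the assay
- Compound 2 `COc1ccc(-n2c(SCc3ccc(F)cc3)nnc2-c2cc(OC)c(OC)c(OC)c2)cc1`: 50700 nM

Compound 1 sits at a limit, > 60000 nM, and has no exact number. Compound 3 `CCOC(=O)CSc1nnc(-c2cc(OC)c(OC)c(OC)c2)n1-c1ccc(OC)cc1` keeps the core of compound 1 and carries one change, ethoxycarbonyl in place of 4-methoxyphenyl on a saturated chain carbon bound to a sulfur. Within the data shown here, the only measured step is an at least 1.1-fold lower number from compound 1 to compound 2 (0.07 log units; that floor lies within the scatter), which puts fluoro in place of methoxy on an aromatic carbon and stays within the scatter. On that single step, no change beyond the scatter is expected in this assay. The expected step is an at least 1.2-fold lower number from compound 1 to compound 3 (0.07 log units; that floor lies within the scatter). Compound 3 is estimated at 50000 nM, with an expected range of 20000 nM to 100000 nM.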

Compound 3, half-maximal inhibitory concentration: > 60000 nM
Compound 3 was reported as a limit (the forecaster's own chance of this, stated with the estimate: 45%); middle value at least 1.2-fold (0.07 log units) from the limit.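

In this assay compound 3 stands at a limit of the assay, so ethoxycarbonyl, which has no ring, brings no readable gain over 4-methoxyphenyl on this saturated chain carbon bound to a sulfur. Among these compounds, the one readable step is an at least 1.1-fold higher number from compound 2 to compound 3 (0.07 log units; that floor lies within the scatter). The step between compound 1 and compound 3 cannot be read, because both values are limits: the limit of > 60000 nM in this assay, at which 2 of the 3 values shown sit.

As far as these compounds go, whether a carboxylic acid or an amine at this place would give a number clear of the limit stays open.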